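The source may report more compounds than this note shows. Statements on the series, on what has been measured and on what is new or still open speak of the compounds shown alone.

Within the data shown here, compound 2 `COc1cc(/C=C/C(C)=O)ccc1OCc1cn(-c2ccc(C=O)cc2)nn1` stands as the higher of the two numbers measured so far in a functional assay on PC-3 cells (Homo sapiens) for antiproliferative activity, read by MTT assay, with a stated time of 48 h; on this read-out lower numbers stand for stronger inhibition and higher numbers for weaker inhibition; compound 2 gives 80700 nM in this assay. Among the measured compounds shown here, its only measured neighbour, compound 1 `COc1cc(/C=C/C(C)=O)ccc1OCc1cn(-c2c(Cl)cccc2Cl)nn1`, gives 3070 nM in this assay, and the one step in hand, a 26-fold higher number from compound 1 to compound 2 (1.42 log units; beyond the scatter), shows how much the group on the aromatic nitrogen counts here. Compound 3 `COc1cc(/C=C/C(C)=O)ccc1OCc1cn(-c2cc(F)cc(Br)c2)nn1` has not yet been measured. It differs from compound 2 in one place: 3-bromo-5-fluorophenyl in place of 4-formylphenyl on an aromatic nitrogen. For the measured compounds named here, the step from compound 1 to compound 2 bears on this change, since it replaced a halogen-bearing phenyl, 2,6-dichlorophenyl, with 4-formylphenyl; compound 3 carries a halogen-bearing phenyl again, though 3-bromo-5-fluorophenyl is not the same group as the one in compound 1. Going by the values given here, because of a 26-fold higher number from compound 1 to compound 2 (1.42 log units; beyond the scatter), a markedly lower number is expected, a step of about a 16-fold lower number from compound 2 to compound 3 (1.21 log units; beyond the scatter), with the size left uncertain by the single step available. Compound 3 is estimated at 5000 nM in this assay, with a range from 1200 nM to 25000 nM.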

Compound 3, half-maximal inhibitory concentration: 56900 nM
Beside the measured number, compound 3's estimate is 11-fold (1.06 log units) below it, and the stated range ends below it.
By their numbers in this assay, from the lowest: compound 1; then compounds 3 and 2 (each within the scatter of the next).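

In this assay, the step of a 1.4-fold lower number from compound 2 to compound 3 (0.15 log units; within the scatter) shows that a halogen-bearing phenyl on the aromatic nitrogen does not by itself bring back a number like that of compound 1: here, 3-bromo-5-fluorophenyl and 4-formylphenyl cannot be told apart. The step of a 19-fold higher number from compound 1 to compound 3 (1.27 log units; beyond the scatter) shows that the two halogen-bearing phenyls, 2,6-dichlorophenyl and 3-bromo-5-fluorophenyl, are not interchangeable at this position, so the earlier contrast between compound 1 and compound 2 cannot be read as a simple contrast between halogen-bearing and formyl-bearing phenyls. No measurement at hand accounts for this difference.

The three compounds leave open whether the number follows the kind of halogen, the number of substituents or their places on the phenyl, since 2,6-dichlorophenyl and 3-bromo-5-fluorophenyl differ in all three. They also leave open how this position would respond to an unsubstituted phenyl, to a phenyl bearing two chlorines in other places, or to a phenyl bearing an amine or a carboxylic acid.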